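The source may hold more compounds than are shown below. What is called first, only, known or untested is meant among the compounds shown, and "the series" means these compounds.

Compound 1 `Cc1cccc(NNC(=O)c2ccccc2NS(=O)(=O)c2cnc(O)nc2O)c1`: > 20000 nM, a limit of the assay
Compound 2 `O=C(NNc1ccccc1Cl)c1ccccc1NS(=O)(=O)c1cnc(O)nc1O`: 5480 nM
Compound 3 `CCCCOc1ccc(C(=O)NNC(=O)c2ccccc2NS(=O)(=O)c2cnc(O)nc2O)cc1`: 4960 nM

In a functional assay on A549 cells (Homo sapiens) for antiproliferative activity, read by MTT assay, with a stated time of 24 h (on this read-out higher numbers stand for weaker inhibition and lower numbers for stronger inhibition), compound 3 gives 4960 nM, within the scatter of compound 2 at 5480 nM. For compound 1, only a limit is available: > 20000 nM.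

Compound 4 `O=C(NNC(=O)c1ccccc1NS(=O)(=O)c1cnc(O)nc1O)c1ccccc1Cl` has not yet been measured. It carries 2-chlorophenyl in place of 4-butoxyphenyl on a carbonyl carbon. Going by the values given here, the only measured step, an at least 3.6-fold lower number from compound 1 to compound 2 (0.56 log units; beyond the scatter), also brings in 2-chlorophenyl, but on an amine nitrogen, so it is only a loose guide to this change. No clear step is therefore expected, in either direction. The expected step is a 1.2-fold higher number from compound 3 to compound 4 (0.08 log units; within the scatter). For compound 4, the estimate is 6000 nM, with an expected range of 2500 nM to 15000 nM.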

Compound 4, half-maximal inhibitory concentration: 5290 nM
Beside the measured number, compound 4's estimate is 1.1-fold (0.05 log units) above it; measured number inside the range.
By their numbers in this assay, from the lowest: compounds 3, 4 and 2 (each within the scatter of the next). At a limit, above all of these: compound 1.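

In this assay, 2-chlorophenyl and 4-butoxyphenyl on the carbonyl carbon cannot be told apart, with a 1.1-fold higher number from compound 3 to compound 4 (0.03 log units; within the scatter), although 4-butoxyphenyl is the larger group and carries a hydrogen-bond acceptor. Replacing 2-chlorophenyl on the amine nitrogen with (2-chlorophenyl)carbonyl also leaves no readable change, with a 1.0-fold lower number from compound 2 to compound 4 (0.02 log units; within the scatter), whereas an at least 3.7-fold lower number from compound 1 to compound 4 (0.57 log units; beyond the scatter) lies beyond the scatter. Compound 1 carries only a limit: the limit of > 20000 nM in this assay, at which 1 of the 4 values shown sits.

On these data alone, whether a carboxylic acid or an amine on that carbonyl carbon would also leave the number in this range remains open.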